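The source may hold more compounds than are shown below. What is called first, only, known or untested is meant among the compounds shown, and "the series" means these compounds.

Measured so far in an ADME assay on HEK293 cells (Homo sapiens) for cytotoxicity, read by WST assay, with a stated time of 48 h; on this read-out lower numbers stand for stronger inhibition and higher numbers for weaker inhibition:
- compound 1 `Cc1cc2c(c(=O)[nH]1)OC(C(=O)CC(C)C)O2`: > 50000 nM
- compound 2 `CC1=CC(=O)[C@@]2(O[C@H]2C(=O)CC(C)C)C(=O)N1`: "not determined" (no result reported)

The value for compound 1 in this assay is a limit of the assay and not a number. Within the data shown here, compound 2 therefore has no single number to stand on; the only other value is the one described by the limit of > 50000 nM in this assay, at which 1 of the 2 values shown sits, which is itself a limit. Among the measured compounds shown here, no step between two measured compounds can be computed here.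

Compound 3 `CC1=CC(=O)C2(OC2C(=O)CC(C)C)C(=O)N1` is the next member to be tested in this assay. Its difference from compound 2 is: the two compounds have the same atoms and bonds; at least one stereo element is drawn with a configuration in one of them and without one in the other: 2 of 2 stereo elements differ; a stereocentre at a saturated ring carbon is drawn R in compound 2 and without a configuration in compound 3; a stereocentre at a saturated ring carbon is drawn R in compound 2 and without a configuration in compound 3

With the same atoms and bonds and only the drawn configurations removed, a step from compound 2 to compound 3 in this assay is expected to be none beyond the scatter; with no number for compound 2, the expectation rests on the limit seen for compound 1. Compound 3 is expected to give about 60000 nM, in a range from 20000 nM to 200000 nM, most likely reported as a limit.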

Compound 3, half-maximal inhibitory concentration: 35900 nM
Compound 3: the middle estimate sits 1.7-fold (0.22 log units) above what was measured, and the stated range covers the measured number.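

Among these compounds, no step from compound 2 to compound 3 can be read in this assay: compound 2 has no number there, while compound 3 gives 35900 nM. As far as these compounds go, whether the drawn configuration at the two saturated ring carbons affects this read-out remains open.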